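The source may report more compounds than this note shows. Statements on the series, on what has been measured and on what is new or still open speak of the compounds shown alone.

Working notes on the series, read in a physicochemical assay for lipophilicity; on this read-out lower numbers stand for lower lipophilicity and higher numbers for higher lipophilicity. Compound 1 `N[C@H]1CC[C@H](Nc2ccc3ncc(-c4cnc(Nc5ccccn5)nc4)n3n2)CC1` gives 1.1, compound 2 `N[C@H]1CC[C@H](Nc2ccc3ncc(-c4cnc(Nc5ncc(C(F)(F)F)cc5F)nc4)n3n2)CC1` gives 1.6, and compound 3 `Fc1cccnc1Nc1ncc(-c2cnc3ccc(N4CCNCC4)nn23)cn1` gives 0.7. Compound 3 holds the lowest of the three numbers, and both other values lie beyond the scatter from it.

The next compound is compound 4 `CN1CCC(Cc2ccc3ncc(-c4cnc(Nc5ncccc5F)nc4)n3n2)CC1`, and the change is (1-methylpiperidin-4-yl)methyl in place of piperazin-1-yl on an aromatic carbon.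

Going by the values given here, no measured step covers this exchange. Among the compounds with values here, the only single-place step available is a number 0.50 log units higher from compound 1 to compound 2 (beyond the scatter), where 3-fluoro-5-(trifluoromethyl)pyridin-2-yl stands in place of pyridin-2-yl on a nitrogen on an aromatic ring. That step lies elsewhere on the molecule, so it offers a rough size for one exchange in this series and not a direct precedent.

With compound 3 at 0.7 as the starting point, a modest upward step of similar size is expected in this assay, held with some caution. The expected move is a number 0.60 log units higher from compound 3 to compound 4 (beyond the scatter). For compound 4 the estimated value is 1.3, with an expected range from 0.8 to 1.8.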

Compound 4, distribution coefficient: 1.3
For compound 4 middle estimate and measured number coincide at the digits printed; the range from low to high includes it.
By their numbers in this assay, from the lowest: compound 3; then compounds 1, 4 and 2 (each within the scatter of the next, the first and the last beyond it).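

In this assay, the exchange of piperazin-1-yl for (1-methylpiperidin-4-yl)methyl on the aromatic carbon of the core gives a number 0.60 log units higher from compound 3 to compound 4 (beyond the scatter). Going by these compounds alone, the only earlier single-place step, a number 0.50 log units higher from compound 1 to compound 2 (beyond the scatter), lay on the aromatic group carried by a nitrogen, so this is the first sign that the read-out also responds to a change at this carbon. The exchange alters several things at once, going from 6 heavy atoms with 1 hydrogen-bond donor and 2 hydrogen-bond acceptors to 8 heavy atoms with 0 hydrogen-bond donors and 1 hydrogen-bond acceptor, and no measurement at hand accounts for the step.

The compounds shown leave open which part of the exchange carries the step: the methyl on the ring nitrogen, the carbon link to the core, or one ring nitrogen giving way to carbon. On these data alone, a 4-methylpiperazin-1-yl group or a piperidin-4-ylmethyl group on this carbon would each hold only part of the exchange, and where either would fall in this assay remains unknown.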